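Swapping a Benzofuran for an Indole in a Cathepsin S Series

The compounds below may be only part of what the source reports. "The series", "measured", "known", "first", "only" and "open" are said of these compounds alone.

Compound 2 `CC(=O)N1CCc2c(c(-c3ccc(C(F)(F)F)cc3)nn2CC(O)CN2CCC(c3coc4cc(F)ccc34)CC2)C1` gives 360 nM in an assay on isolated protein for inhibition of cathepsin S (Homo sapiens) (a higher number here means a weaker inhibitor, a lower number a stronger inhibitor), the highest of the three numbers in hand. Compound 3 `COC(=O)c1sc2cc(F)ccc2c1C1CCN(CC(O)Cn2nc(-c3ccc(C(F)(F)F)cc3)c3c2CCN(S(C)(=O)=O)C3)CC1` gives 130 nM in this assay, and compound 1 `Cn1c(=O)n(C2CCN(CCCn3nc(-c4ccc(Cl)c(Cl)c4)c4c3CCN(S(C)(=O)=O)C4)CC2)c2ccccc21` gives 10 nM; both gaps to compound 2 lie beyond the scatter. Compound 4 `CC(=O)N1CCc2c(c(-c3ccc(C(F)(F)F)cc3)nn2CC(O)CN2CCC(c3c[nH]c4ccc(Cl)cc34)CC2)C1` is compound 2 with 5-chloro-1H-indol-3-yl in place of 6-fluoro-1-benzofuran-3-yl on a saturated ring carbon. For the measured compounds named here, no pair of measured compounds shows this exchange on its own, so nothing among the numbers fixes its size or direction. From the compounds shown here alone, the account therefore expects a step in this assay no larger than the scatter, a 1.2-fold lower number from compound 2 to compound 4 (0.08 log units; within the scatter), with either direction still open. For compound 4 the estimated value is 300 nM, with a range from 100 nM to 900 nM.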

Compound 4, half-maximal inhibitory concentration: 95 nM
Estimate against measurement, compound 4: 3.2-fold (0.50 log units) above; measured number outside the range, below it.
By their numbers in this assay, from the lowest: compound 1; then compounds 4 and 3 (each within the scatter of the next); then compound 2.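

In this assay the exchange of 6-fluoro-1-benzofuran-3-yl for 5-chloro-1H-indol-3-yl on this saturated ring carbon gives a 3.8-fold lower number from compound 2 to compound 4 (0.58 log units; beyond the scatter) and so shows that this position responds to the group it carries. The two groups have equal heavy-atom counts and the same ring types, yet the entering one differs in its hetero atom, its halogen and its hydrogen-bond donor. No measured evidence here accounts for the step.

The compounds shown leave open which of these differences carries the step. A 5-chloro-1-benzofuran-3-yl or 6-fluoro-1H-indol-3-yl group at this position would separate them.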